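From methyl to 4-cyanophenyl on the carbonyl carbon

The source may hold more compounds than are shown below. What is called first, only, known or untested is meant among the compounds shown, and "the series" means these compounds.

Of the compounds shown here, three sharing one core have been tested in a toxicity assay on THP-1 cells (Homo sapiens) for inhibition; a lower number here means that less compound is tolerated, a higher number that more compound is tolerated: compound 1 (`COc1ccc(-c2cnc(NC(=O)C3CCNCC3)n2C)cc1`), compound 2 (`COc1ccc(-c2cnc(NC(=O)c3cnc[nH]3)n2C)cc1`) and compound 3 (`COc1ccc(-c2cnc(NC(C)=O)n2C)cc1`). Compound 3 gives > 100000 nM, which is a limit and not a number. Compound 1 also gives only a limit, > 100000 nM. Compound 2 likewise gives only a limit, > 100000 nM. All three thus sit at the limit of > 100000 nM in this assay, at which 3 of the 3 values shown sit.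

Compound 4 (`COc1ccc(-c2cnc(NC(=O)c3ccc(C#N)cc3)n2C)cc1`) carries 4-cyanophenyl in place of methyl on a carbonyl carbon. The measured steps at this same place are a step that the two limits leave unreadable from compound 1 to compound 3, a step that the two limits leave unreadable from compound 2 to compound 3 and a step that the two limits leave unreadable from compound 1 to compound 2, so none offers a readable size. Neither compound 1 nor compound 2 came off the limit in this assay, yet neither carries a six-membered aromatic ring of carbon only. The expected result is therefore no step beyond the scatter, and any departure is expected to be downward, towards less compound tolerated: the estimated step is a number no higher from compound 3 to compound 4 (the limit leaves the size open). Compound 4 is expected at 100000 nM, with an estimated range from 30000 nM to 150000 nM.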

Compound 4, half-maximal cytotoxic concentration: > 100000 nM
Compound 4 was reported as a limit; the forecaster's own chance of this, stated with the estimate: 70%; the middle value lies on the limit itself.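

In this assay compound 4 gives > 100000 nM, which is a limit and not a number. Among these compounds, no step from compound 1, compound 2 or compound 3 to compound 4 can be read. The compounds shown leave open how far any group on the carbonyl carbon changes this read-out: the limit of > 100000 nM in this assay, at which 4 of the 4 values shown sit.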